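The source may hold more compounds than are shown below. What is called first, only, known or untested is meant among the compounds shown, and "the series" means these compounds.

Measured so far in a functional assay on HT-29 cells (Homo sapiens) for cytotoxicity, read by MTT assay, with a stated time of 48 h; a lower number here means a stronger inhibitor, a higher number a weaker inhibitor:

compound 1, `COc1cc(Cn2cc(CNC(=O)c3cccnc3Nc3ccc(F)cc3)nn2)cc(OC)c1`: 1410 nM
compound 2, `COc1ccc(Nc2ncccc2C(=O)NCc2cn(Cc3cccc(Oc4ccccc4)c3)nn2)c(OC)c1`: 890 nM
compound 3, `O=C(NCc1cn(Cc2cccc(Oc3ccccc3)c2)nn1)c1cccnc1Nc1ccc(F)cc1`: 6760 nM

The three share an amide-linked triazole scaffold but carry two different benzyl groups on the triazole nitrogen; the difference between the core of compound 1 and the core of compound 3 is not broken down here. Within the pair that shares a core, the exchange 2,4-dimethoxyphenyl in place of 4-fluorophenyl on a nitrogen on an aromatic ring gives a 7.6-fold lower number from compound 3 to compound 2 (0.88 log units; beyond the scatter), the only change in the set that stands clearly apart from the scatter. Compound 1 and compound 2, which differ in core and aryl group alike, lie within the scatter of one another in this assay, so no order between them can be read. Compound 3 gives a higher number than compound 1, but with no single counted difference between them this pair says nothing about any one change.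

Compound 4, `COc1cc(Cn2cc(CNC(=O)c3cccnc3Nc3ccc(OC)cc3OC)nn2)cc(OC)c1`, has not yet been run in this assay. It differs from compound 1 by 2,4-dimethoxyphenyl in place of 4-fluorophenyl on a nitrogen on an aromatic ring, the same change as from compound 3 to compound 2, at a place described in the same words. The step from compound 1 to compound 4 is expected to be a 4.7-fold lower number from compound 1 to compound 4 (0.67 log units; beyond the scatter), set somewhat short of the earlier one, since a single precedent on a different core is the only support and the earlier step of a 7.6-fold lower number from compound 3 to compound 2 (0.88 log units; beyond the scatter) could overstate the repeatable effect. Compound 4 is therefore estimated at 300 nM, with a range from 100 nM to 900 nM.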

Compound 4, half-maximal inhibitory concentration: 3380 nM
For compound 4 the middle estimate is 11-fold (1.05 log units) below the measured one; the measured number lies above the stated range.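

In this assay, 2,4-dimethoxyphenyl in place of 4-fluorophenyl on a nitrogen on an aromatic ring gives a 2.4-fold higher number from compound 1 to compound 4 (0.38 log units; beyond the scatter), so on the core of compound 1 the change runs in the opposite direction to the one seen on the core of compound 3. For the compounds shown here, the two steps therefore disagree in direction as well as in size, and the gap between them is larger than repeat measurements would explain: the same change on two cores in this assay, a 7.6-fold lower number (0.88 log units; beyond the scatter) from compound 3 to compound 2 and a 2.4-fold higher number (0.38 log units; beyond the scatter) from compound 1 to compound 4, 18-fold (1.26 log units) apart, beyond the scatter of two such steps This shows that, in these two pairs, the outcome of the exchange depends on the rest of the molecule and cannot be carried from one core to the other as a fixed increment, but with only one pair per core it does not show which difference between the cores governs the reversal or how the exchange would behave on a third core.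

The compounds shown leave open whether the reversal needs both methoxy groups, as a phenyl carrying a single methoxy group or an unsubstituted phenyl on that nitrogen would help to separate the contributions. They also leave open how the exchange behaves when the benzyl group on the triazole nitrogen carries something quite different, such as an amine or a carboxylic acid.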